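Swapping Methoxy for Carboxy on a Shared Core

This account rests on a few compounds, and the source may have more. Where it says the series, first, only, none or still open, it means among the compounds named here.

Compound 1 `O=c1cc(COc2cccc(OCC3CCOCC3)c2)[nH]c2ccccc12` was measured in an in vitro ADME assay on microsomes from liver (Homo sapiens) for metabolic stability, tested at 0.2 uM (on this read-out lower numbers stand for slow clearance and higher numbers for fast clearance), and gives 78 mL/min/kg. Compound 2 `COc1ccc2[nH]c(COc3cccc(OCC4CCOCC4)c3)c(C)c(=O)c2c1` was submitted to this assay too, where compound 2 gives "not determined" (no result reported), so compound 2 has no number to stand on. Compound 3 `Cc1c(COc2cccc(OCC3CCOCC3)c2)[nH]c2ccc(C(=O)O)cc2c1=O` differs from compound 2 in one place: carboxy in place of methoxy on an aromatic carbon. Among the measured compounds shown here, with no measured pair sharing this change, the size of the step in this assay cannot be read from the data; only the single number for compound 1 offers a point of reference, and the direction remains open. Compound 3 is expected to give 25 mL/min/kg, within a range of 8 mL/min/kg to 70 mL/min/kg.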

Compound 3, clearance: < 20 mL/min/kg
Compound 3: no number, only a limit; the forecaster's own chance of this, stated with the estimate: 15%; middle value at least 1.2-fold (0.09 log units) away from the limit.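

No step can be read between compound 2 and compound 3, as compound 2 has no number. In this assay compound 3 gives < 20 mL/min/kg, a limit and not a number. Going by these compounds, the size and direction of the change in clearance from swapping methoxy for carboxy on this core remain open.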